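The compounds below may be only part of what the source reports. "The series", "measured", "known", "first", "only" and "open" are said of these compounds alone.

Compound 1 `O=C(Nc1cccc(/C=C/C(=O)c2nc3ccccc3[nH]2)c1)c1cccc(Cl)c1` gives 1120 nM.
Compound 2 `O=C(Nc1cccc(/C=C/C(=O)c2nc3ccccc3[nH]2)c1)c1ccc(Cl)cc1` gives 2270 nM.
Compound 3 `O=C(Nc1cccc(/C=C/C(=O)c2nc3ccccc3[nH]2)c1)c1ccc(Br)cc1` gives 2230 nM.

All three share one core and differ only in the ring on the carbonyl carbon of the amide. In a functional assay on HCT-116 cells (Homo sapiens) for antiproliferative activity, read by MTT assay, with a stated time of 48 h (on this read-out lower numbers stand for stronger inhibition and higher numbers for weaker inhibition), compound 3 stands second highest of the three numbers. Its nearest neighbour is compound 2, and the step of a 1.0-fold lower number from compound 2 to compound 3 (0.01 log units; within the scatter) lies within the scatter, so the two cannot be told apart. The furthest is compound 1, and the step of a 2.0-fold higher number from compound 1 to compound 3 (0.30 log units; within the scatter) also lies within the scatter, though at its edge.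

Compound 4 `O=C(Nc1cccc(/C=C/C(=O)c2nc3ccccc3[nH]2)c1)c1cccc(C(F)(F)F)c1` has not been measured. It differs from compound 3 in that (3-(trifluoromethyl)phenyl in place of 4-bromophenyl on a carbonyl carbon). Within the data shown here, two measured steps bear on this. The step of a 2.0-fold higher number from compound 1 to compound 3 (0.30 log units; within the scatter) and the step of a 2.0-fold higher number from compound 1 to compound 2 (0.31 log units; beyond the scatter) both show that a 3-chlorophenyl gave a somewhat lower number than a 4-substituted phenyl, though only one of them passes beyond the scatter. Among the measured compounds shown here, no measured compound carries a trifluoromethyl group, so that part of the change has no precedent here. The return to a 3-substituted phenyl is expected to give at most a modest step downward, a 1.7-fold lower number from compound 3 to compound 4 (0.23 log units; within the scatter), in this assay. Compound 4 is therefore estimated at 1300 nM, within 500 nM to 3300 nM.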

Compound 4, half-maximal inhibitory concentration: 3360 nM
Compound 4: middle estimate off by 2.6-fold (0.41 log units), on the low side; measured number above the stated range.
By their numbers in this assay, from the lowest: compounds 1, 3, 2 and 4 (each within the scatter of the next, the first and the last beyond it).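

In this assay the move from 3-chlorophenyl to 3-(trifluoromethyl)phenyl on the carbonyl carbon gives a 3.0-fold higher number from compound 1 to compound 4 (0.48 log units; beyond the scatter) and this lies beyond the scatter, so the group on the ring counts here, and the number in the name of the ring does not settle the outcome alone. Compound 4 cannot be told apart from the compounds carrying 4-bromophenyl or 4-chlorophenyl, since a 1.5-fold higher number from compound 3 to compound 4 (0.18 log units; within the scatter) and a 1.5-fold higher number from compound 2 to compound 4 (0.17 log units; within the scatter) both lie within the scatter. The earlier hint that a 3-substituted phenyl gives the lower number therefore rests on compound 1 alone, and compound 4 goes against it.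

Nothing shown here measures why chloro and trifluoromethyl part ways on this ring. Still open, going by these compounds, is whether the low number of compound 1 is special to chloro or would also appear with 3-bromophenyl, 3-fluorophenyl or 3-methoxyphenyl, and whether an unsubstituted phenyl, or an amine or a carboxylic acid on this ring, would fall with compound 1 or with compound 4.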